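The source may hold more compounds than are shown below. What is called first, only, known or untested is meant among the compounds shown, and "the series" means these compounds.

Three compounds that share one core have been examined in a functional assay on the whole organism for positive allosteric modulation, with Rattus norvegicus as the target; on this read-out higher numbers stand for an effect only at larger amounts of compound and lower numbers for an effect already at smaller amounts. Compound 1 `CC(=O)N1CCN=C(c2cccc(Cl)c2)c2c(C)nn(C)c21` gives in this assay only a limit, > 10 mg/kg, and no number. Compound 2 `Cc1nn(C)c2c1C(c1cccc(Br)c1)=NCCN2` gives 0.63 mg/kg in this assay, the lowest of the two numbers recorded so far. Compound 3 `CCc1nn(C)c2c1C(c1cccc(Br)c1)=NCCN2` gives 1.25 mg/kg in this assay. Among the compounds with values here, the only measured step, a 2.0-fold higher number from compound 2 to compound 3 (0.30 log units; within the scatter), brings methyl in place of hydrogen on a saturated chain carbon bound to an aromatic carbon and stays within the scatter.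

Compound 4 `Cc1nn(C)c2c1C(c1cccc(N)c1)=NCCN2` remains to be tested in this assay. It differs from compound 2 in one place: amino in place of bromo on an aromatic carbon. Within the data shown here, no measured step touches the six-membered aromatic ring of carbon only, so the recorded data give no direct guide to what an amino in place of bromo will do, and the expectation rests on the value of compound 2 alone with a broad range around it. Compound 4 is therefore expected to give about 1.25 mg/kg in this assay, somewhere between 0.4 mg/kg and 5 mg/kg, which would amount to an expected step of a 2.0-fold higher number from compound 2 to compound 4 (0.30 log units; within the scatter).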

Compound 4, minimum effective dose: 2.5 mg/kg
Compound 4: the middle estimate sits 2.0-fold (0.30 log units) below what was measured; low and high end bracket the measured number.
By their numbers in this assay, from the lowest: compounds 2, 3 and 4 (each within the scatter of the next, the first and the last beyond it). At a limit, above all of these: compound 1.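

Amino in place of bromo, on an aromatic carbon of the six-membered aromatic ring of carbon only and meta to a large group, gives in this assay a 4.0-fold higher number from compound 2 to compound 4 (0.60 log units; beyond the scatter), the first measured change at this position. This step lies beyond the scatter, unlike the one measured earlier on the saturated chain carbon, yet compound 4 still gives a number and not a limit. Nothing recorded here accounts for the size of this step.

With only bromo and amino compared at this position, the compounds shown leave open whether the loss of bromo or the arrival of amino sets the step. Also open, as far as these compounds go, is how a methoxy, a nitrile or a plain hydrogen at the same position would compare with compound 2.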